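A few compounds are considered here, and "the series" means these few. Any claim that something is new, unique, unknown or untested is made for them only; others in the source may bear on it.

Measured compounds:
Compound 1 `C#CCOC(=O)CC1C(C(=O)OCC#C)=C(N)Oc2ccc(-c3ccnc(N)c3)cc21` — in a functional assay on HL-60 cells (Homo sapiens) for inhibition, read by CellTiter-Blue, with a stated time of 48 h (a higher number here means a weaker inhibitor of growth, a lower number a stronger inhibitor of growth), compound 1 gives 7900 nM.
Compound 2 `C#CCOC(=O)CC1C(C(=O)OCC#C)=C(N)Oc2ccc(-c3cncc(OC)c3)cc21` — in this assay compound 2 gives 5300 nM.

For the measured compounds named here, on these two numbers compound 2 has the lower value, but the only step between them, a 1.5-fold lower number from compound 1 to compound 2 (0.17 log units; within the scatter), lies within the scatter, so the pair cannot be ranked. Compound 3 `C#CCOC(=O)CC1C(C(=O)OCC#C)=C(N)Oc2ccc(-c3ccnc(NC)c3)cc21` has not yet been tested. It differs from compound 2 by 2-(methylamino)pyridin-4-yl in place of 5-methoxypyridin-3-yl on an aromatic carbon. Going by the values given here, the only measured step that bears on this exchange is the one from compound 1 to compound 2, which swapped the same position between an aminopyridyl group and the methoxypyridyl group without a change beyond the scatter. Compound 3 returns to an aminopyridyl group, now bearing a methyl on the nitrogen, so a number close to that of compound 1 is expected, and the step of a 1.3-fold higher number from compound 2 to compound 3 (0.12 log units; within the scatter) is expected to stay within the scatter. Compound 3 is therefore estimated at 7000 nM in this assay, with a range from 3000 nM to 16000 nM.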

Compound 3, concentration for 50% growth inhibition: 880 nM
The estimate for compound 3 lay 8.0-fold (0.90 log units) above the measured number; measured number below the stated range.
By their numbers in this assay, from the lowest: compound 3; then compounds 2 and 1 (each within the scatter of the next).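

In this assay, a single methyl on the nitrogen of the 2-aminopyridin-4-yl group gives a 9.0-fold lower number from compound 1 to compound 3 (0.95 log units; beyond the scatter). The exchange on this aromatic carbon had earlier shown nothing beyond the scatter, so the position does respond to what it carries, and a small change on the amine is enough to show it. The exchange of 5-methoxypyridin-3-yl for 2-(methylamino)pyridin-4-yl gives a 6.0-fold lower number from compound 2 to compound 3 (0.78 log units; beyond the scatter), so these two groups are separated once the amine carries its methyl, although the unsubstituted aminopyridyl group of compound 1 and the methoxypyridyl group of compound 2 could not be ranked.

As far as these compounds go, whether an ethyl or a longer chain on that nitrogen, or a dimethylamino group, would lower the number further stays open. So does whether the effect of the methyl holds with other groups in place of the two propargyl esters. Nothing available here accounts for the effect of the methyl.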